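This account rests on a few compounds, and the source may have more. Where it says the series, first, only, none or still open, it means among the compounds named here.

Measured in a functional assay for inhibition, with Rattus norvegicus as the target; on this read-out lower numbers stand for stronger inhibition and higher numbers for weaker inhibition:
- Compound 1 `CC(C)(C)/N=c1\c(O)c(O)\c1=N/Cc1cccc(F)c1`: 2400 nM
- Compound 2 `CC(C)(C)/N=c1\c(O)c(O)\c1=N/Cc1ccccc1`: 3400 nM

Within the data shown here, compound 2, at 3400 nM, lies within the scatter of its only measured neighbour, compound 1, at 2400 nM. The next compound, compound 3 `CC(C)(C)/N=c1\c(O)c(O)\c1=N/Cc1ccc(F)cc1`, differs from compound 2 by one change: fluoro in place of hydrogen on an aromatic carbon. This is fluoro in place of hydrogen on an aromatic carbon, para to a large group. Among the measured compounds shown here, only one measured step bears on it: a 1.4-fold higher number from compound 1 to compound 2 (0.15 log units; within the scatter), which is the same exchange of fluoro and hydrogen in the opposite sense. For the measured compounds named here, no measurement yet covers fluoro at the place it occupies in compound 3, so this single step is only a loose guide. On that basis, no change beyond the scatter is expected, and the expected step is a 1.3-fold lower number from compound 2 to compound 3 (0.10 log units; within the scatter). For compound 3 the estimated value is 2700 nM, with an expected range of 1300 nM to 5500 nM.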

Compound 3, half-maximal inhibitory concentration: 1500 nM
Estimate against measurement, compound 3: 1.8-fold (0.26 log units) above; the measured number falls inside the stated range.
By their numbers in this assay, from the lowest: compounds 3, 1 and 2 (each within the scatter of the next, the first and the last beyond it).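

In this assay fluoro in place of hydrogen on an aromatic carbon, para to a large group, gives a modest step (a 2.3-fold lower number from compound 2 to compound 3 (0.36 log units; beyond the scatter)). Among these compounds, the earlier exchange of the same two substituents at another place on the ring (a 1.4-fold higher number from compound 1 to compound 2 (0.15 log units; within the scatter)) stayed within the scatter, so this position is the first at which the change is seen to pass beyond it. Even so, compound 1 and compound 3 lie within the scatter of each other, so the two placements of fluoro are not told apart.

The compounds shown leave open whether chloro or methoxy at this position would give a similar step, and whether the step would hold with a group other than tert-butyl on the shared core. Nothing measured here gives a reason for the step.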